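The compounds below may be only part of what the source reports. "The series", "measured", "known", "first", "only" and "open" are said of these compounds alone.

Of the compounds shown here, three built on a shared core have been tested in a toxicity assay on WI-38 cells (Homo sapiens) for inhibition, read by MTT assay, with a stated time of 48 h; on this read-out lower numbers stand for stronger inhibition and higher numbers for weaker inhibition. Compound 1 `Cc1ccc(/C=C2\SC(=O)N(CCNC(=O)Nc3c(C)n(C)n(-c4ccccc4)c3=O)C2=O)cc1` gives 48100 nM, compound 2 `COc1ccc(/C=C2\SC(=O)N(CCNC(=O)Nc3c(C)n(C)n(-c4ccccc4)c3=O)C2=O)cc1` gives 34500 nM, and compound 3 `Cc1c(NC(=O)NCCN2C(=O)S/C(=C\c3ccc([N+](=O)[O-])cc3)C2=O)c(=O)n(-c2ccccc2)n1C` gives 76400 nM. Two steps fix where compound 3 stands: a 1.6-fold higher number from compound 1 to compound 3 (0.20 log units; within the scatter), and a 2.2-fold higher number from compound 2 to compound 3 (0.35 log units; beyond the scatter). The next structure is compound 4 `COc1cc(/C=C2\SC(=O)N(CCNC(=O)Nc3c(C)n(C)n(-c4ccccc4)c3=O)C2=O)cc(OC)c1OC`, and the change is 3,4,5-trimethoxyphenyl in place of 4-nitrophenyl on a double-bonded chain carbon bound to a double-bonded ring carbon. In short, 3,4,5-trimethoxyphenyl replaces 4-nitrophenyl. Among the measured compounds shown here, the closest precedent is compound 2, which carries methoxy where compound 3 carries nitro, and that pair shows a 2.2-fold higher number from compound 2 to compound 3 (0.35 log units; beyond the scatter). Read backwards, this points to a lower number when nitro gives way to methoxy. The swap of methyl for methoxy was small, at a 1.4-fold lower number from compound 1 to compound 2 (0.14 log units; within the scatter). For the measured compounds named here, no tested compound carries three methoxy groups, so this is an extrapolation and the range must stay wide. The expected change in this assay is a modest drop, estimated as a 1.9-fold lower number from compound 3 to compound 4 (0.28 log units; within the scatter). For compound 4 the estimated value is 40000 nM, with an expected range of 20000 nM to 80000 nM.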

Compound 4, half-maximal inhibitory concentration: 51500 nM
Beside the measured number, compound 4's estimate is 1.3-fold (0.11 log units) below it; the range from low to high includes it.
By their numbers in this assay, from the lowest: compounds 2, 1, 4 and 3 (each within the scatter of the next, the first and the last beyond it).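

Even the 3,4,5-trimethoxyphenyl group, with three methoxy groups on the ring, leaves the number in this assay within the scatter of every earlier compound: a 1.5-fold lower number from compound 3 to compound 4 (0.17 log units; within the scatter), a 1.5-fold higher number from compound 2 to compound 4 (0.17 log units; within the scatter) and a 1.1-fold higher number from compound 1 to compound 4 (0.03 log units; within the scatter). Among the compounds shown here, the only gap beyond the scatter at this place therefore remains the one between compound 2 and compound 3, and compound 4 does not extend the spread of the series. The data shown offer no explanation for this small response.

As far as these compounds go, whether a carboxylic acid or an amine on the phenyl ring would move the number beyond the scatter remains open. So does the effect of replacing the phenyl ring with a pyridine ring, or of any change to the shared core, which all four compounds keep.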